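Swapping a Hydroxy-Methoxyphenyl for a Styryl Chain

The source may hold more compounds than are shown below. What is called first, only, known or untested is meant among the compounds shown, and "the series" means these compounds.

Compound 1 `CC(C)=C1C(=O)N(c2ccc(Cl)cc2)N(c2ccc(Cl)cc2)C1=O` gives 39000 nM in a functional assay on MGC-803 cells (Homo sapiens) for cytotoxicity, read by MTT assay, with a stated time of 72 h; on this read-out lower numbers stand for stronger inhibition and higher numbers for weaker inhibition.
Compound 2 `COc1cccc(C=C2C(=O)N(c3ccc(Cl)cc3)N(c3ccc(Cl)cc3)C2=O)c1O` gives 24300 nM in this assay.
Compound 3 `CC(=C1C(=O)N(c2ccc(Cl)cc2)N(c2ccc(Cl)cc2)C1=O)c1ccc(O)cc1` gives 42800 nM in this assay.

Compound 2 has the lowest of the three numbers, but all three lie within the usual scatter of one another, so no ordering among them can be claimed. Compound 4 `O=C1C(=C/C=C/c2ccccc2)C(=O)N(c2ccc(Cl)cc2)N1c1ccc(Cl)cc1` differs from compound 2 by 2-phenylethenyl in place of 2-hydroxy-3-methoxyphenyl on a double-bonded chain carbon bound to a double-bonded ring carbon. Among the compounds with values here, no measured step touches this same position, so only an indirect hint exists: the step of a 1.1-fold higher number from compound 1 to compound 3 (0.04 log units; within the scatter) shows that a large change of group on a neighbouring chain carbon left the number unmoved. By that analogy, and given how narrow the range of the three values is, the step of a 1.3-fold higher number from compound 2 to compound 4 (0.12 log units; within the scatter) is expected to stay within the scatter. Compound 4 is therefore estimated at 32000 nM, with a range from 12000 nM to 85000 nM.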

Compound 4, half-maximal inhibitory concentration: 5100 nM
For compound 4 the middle estimate is 6.3-fold (0.80 log units) above the measured one; measured number below the stated range.
By their numbers in this assay, from the lowest: compound 4; then compounds 2, 1 and 3 (each within the scatter of the next).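

Within the data shown here, on the chain carbon bound to a double-bonded ring carbon, the group matters in this assay: swapping 2-hydroxy-3-methoxyphenyl for 2-phenylethenyl gives a 4.8-fold lower number from compound 2 to compound 4 (0.68 log units; beyond the scatter), the first step here to clear the scatter. The entering group has one double bond outside aromatic rings and no hydrogen-bond donors or acceptors, whereas the leaving group has both donor and acceptors. Nothing measured here accounts for this step.

From the compounds shown here alone, the swap changes both features at once, so it remains open which one carries the step. A plain phenyl group or an amine at this place would be further untested cases.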